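This account rests on a few compounds, and the source may have more. Where it says the series, first, only, none or still open, it means among the compounds named here.

Of the compounds shown here, three of a shared core have been measured in a functional assay on the whole organism with Mus musculus as the target, in the maximal electroshock model; a lower number here means that less compound is needed, a higher number that more compound is needed for the effect. Compound 1 `Cc1nn2cnnc2cc1Cc1c(Cl)cccc1Cl` gives 6.2 mg/kg. Compound 2 `Cc1nn2c(C)nnc2cc1Cc1ccccc1Cl` gives 30.5 mg/kg. Compound 3 `Cc1nn2c(N)nnc2cc1Cc1ccccc1Cl` gives 17.4 mg/kg. Among the measured compounds shown here, on these three numbers compound 3 has the second highest value; its nearest neighbour is compound 2, and the only step that links two measured compounds differing in one place, a 1.8-fold lower number from compound 2 to compound 3 (0.24 log units; within the scatter), stays within the scatter. Compound 1 gives a number lower than that of compound 3 by an amount that lies beyond the scatter, but compound 1 and compound 3 differ in two places, so no single step can be read from that pair.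

The next compound, compound 4 `Cc1nn2c(N)nnc2cc1Cc1c(Cl)cccc1Cl`, differs from compound 3 by chloro in place of hydrogen on an aromatic carbon. For the measured compounds named here, no measured step isolates this change: the only compound carrying the second chloro group, compound 1, also lacks the amino group. Going by the values given here, what the numbers do show is that the one compound with two chloro groups has the lowest value seen so far, while the two compounds with a single chloro group have the two higher values. On that basis a step to a lower number, a 1.9-fold lower number from compound 3 to compound 4 (0.29 log units; within the scatter), is expected, and compound 4 is estimated at 9 mg/kg, within a range from 4 mg/kg to 20 mg/kg.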

Compound 4, dose for half-maximal effect: 9.2 mg/kg
Estimate against measurement, compound 4: 1.0-fold (0.01 log units) below; measured number inside the range.
By their numbers in this assay, from the lowest: compounds 1, 4, 3 and 2 (each within the scatter of the next, the first and the last beyond it).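

In this assay, the second chloro group, on an aromatic carbon ortho to a large group and meta to a chloro group, now has a direct comparison of its own, a 1.9-fold lower number from compound 3 to compound 4 (0.28 log units; within the scatter), and this single change cannot be told apart from the ordinary variation between repeated measurements. The amino group, so far compared only with methyl, is now also compared with hydrogen on compounds carrying two chloro groups, a 1.5-fold higher number from compound 1 to compound 4 (0.17 log units; within the scatter), and this change too cannot be distinguished from that variation, so neither of these single changes at its position has a demonstrated effect in this model. No measurement is available that would explain these results in terms of the compounds' properties.

The compounds shown leave open whether another group at the chloro position, such as fluoro, methoxy or trifluoromethyl, would give a change large enough to stand clear of the scatter. They also leave open what a longer chain such as ethyl or propyl, or a carboxylic acid, would do on the aromatic carbon that carries the amino group in compound 4.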